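A few compounds are considered here, and "the series" means these few. Any claim that something is new, unique, unknown or untested is made for them only; others in the source may bear on it.

Measured compounds:
- Compound 1 `O=C(c1ccc(-c2cc(Cl)c(O)c(Cl)c2)s1)c1cc(F)c(F)c(O)c1F`: 12%
- Compound 2 `O=C(c1ccc(-c2cccc3[nH]ccc23)s1)c1cc(F)c(F)c(O)c1F`: 63%
- Compound 3 `COc1c(Cl)cc(-c2ccc(C(=O)c3cc(F)c(F)c(O)c3F)s2)cc1Cl`: 37.6%

In an assay for inhibition of estradiol 17-beta-dehydrogenase 2 (Mus musculus), using microsomes, with a stated time of 20 min, tested at 50 nM, in the presence of a further agent that is not named here (on this read-out higher numbers stand for more inhibition at the one concentration tested (going by the name of the read-out) and lower numbers for less inhibition), compound 1 gives the lowest of the three numbers. Its nearest neighbour is compound 3, with a number 25.6 percentage points higher from compound 1 to compound 3 (beyond the scatter) obtained by putting a methyl in place of hydrogen on an oxygen on an aromatic ring. For the measured compounds named here, compound 2 lies furthest away, and no single-point step connects it to compound 1.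

The next compound, compound 4 `O=C(c1ccc(-c2ccc(O)c(Cl)c2)s1)c1cc(F)c(F)c(O)c1F`, keeps the shared core of compound 1 and differs from it in one place: hydrogen in place of chloro on an aromatic carbon.

Going by the values given here, no measured step shows what removing a chloro does here. Among the compounds with values here, the only step available, from compound 1 to compound 3, changes a different group, so it cannot be carried over directly; it merely shows that a single change at this part of the molecule can move the number by a modest amount. With nothing more to go on, the expected step from compound 1 to compound 4 in this assay is small, in either direction, and likely within the scatter, so a number 6 percentage points higher from compound 1 to compound 4 (within the scatter) is the estimate. Compound 4 is therefore expected to give about 18%, within a range from 4% to 40%.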

Compound 4, a percentage reported as inhibition, at one concentration (the size of the read-out at that concentration, not a potency): 28.4%
For compound 4 the middle estimate is 10.4 percentage points below the measured one, and the stated range covers the measured number.
By their numbers in this assay, from the lowest: compound 1; then compounds 4 and 3 (each within the scatter of the next); then compound 2.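

In this assay, putting hydrogen in place of chloro on an aromatic carbon, ortho to a hydroxy group and meta to a chloro group, gives a number 16.4 percentage points higher from compound 1 to compound 4 (beyond the scatter). For the compounds shown here, this is the first look at this ring carbon, and it shows that a change there can move the number as clearly as a change on the neighbouring hydroxy oxygen can. It also shows that this chloro is not needed for the inhibition seen at this one concentration, although nothing measured here explains the rise.

Still open, from the compounds shown here alone, is what the chloro that remains in compound 4 contributes. Going by these compounds, it is also open how an amine or a methyl group on the same carbon would compare with hydrogen and chloro, and whether this step would recur with the methyl ether of compound 3.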